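The source may report more compounds than this note shows. Statements on the series, on what has been measured and on what is new or still open speak of the compounds shown alone.

Measured compounds:
compound 1 `COc1cc(-c2nc3cc(/C=C4\SC(=O)N(CC(=O)N5CCCCC5)C4=O)ccc3[nH]2)cc(OC)c1OC` — 23300 nM
compound 2 `COc1cc(OC)c(-c2nc3cc(/C=C4\SC(=O)N(CC(=O)N5CCCCC5)C4=O)ccc3[nH]2)cc1OC` — 6890 nM

For the measured compounds named here, in a functional assay on HeLa cells (Homo sapiens) for inhibition, read by MTT assay, with a stated time of 48 h (a lower number here means a stronger inhibitor, a higher number a weaker inhibitor), compound 1 gives the highest of the two numbers; the only other point is compound 2, and the step of a 3.4-fold lower number from compound 1 to compound 2 (0.53 log units; beyond the scatter) concerns the trimethoxyphenyl ring, not the chain on the ring nitrogen. Compound 3 `COc1cc(-c2nc3cc(/C=C4\SC(=O)N(Cc5cccc(C)c5)C4=O)ccc3[nH]2)cc(OC)c1OC` differs from compound 1 by 3-methylphenyl in place of (piperidin-1-yl)carbonyl on a saturated chain carbon bound to an amide-type nitrogen in a ring. Going by the values given here, no measured step bears on this change, so no direction can be read from the series. Compound 3 is therefore expected near compound 1, with a broad range: estimate 18000 nM (5000 nM to 70000 nM), a step of a 1.3-fold lower number from compound 1 to compound 3 (0.11 log units; within the scatter).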

Compound 3, half-maximal inhibitory concentration: 1440 nM
Compound 3: the middle estimate sits 13-fold (1.10 log units) above what was measured, outside the stated range (below it).
By their numbers in this assay, from the lowest: compound 3; then compound 2; then compound 1.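

In this assay, the position on a saturated chain carbon bound to an amide-type nitrogen in a ring responds strongly: 3-methylphenyl in place of (piperidin-1-yl)carbonyl gives a 16-fold lower number from compound 1 to compound 3 (1.21 log units; beyond the scatter) as a large step. This change removes the carbonyl and the piperidine ring together, so the step cannot be assigned to either part. No measurement available here accounts for the step.

Still open, going by these compounds, is whether a plain benzyl or 3-chlorobenzyl group would match 3-methylbenzyl. Also open, on these data alone, is whether 2,4,5-trimethoxyphenyl and 3-methylbenzyl combine to give a still lower number.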